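The source may hold more compounds than are shown below. What is called first, only, known or untested is meant among the compounds shown, and "the series" means these compounds.

Three pyrazoline compounds have been tested so far in an assay on isolated protein for inhibition of DNA topoisomerase 1 (Homo sapiens), with a stated time of 30 min, tested at 100 uM (on this read-out lower numbers stand for less inhibition and higher numbers for more inhibition at the one concentration tested (going by the name of the read-out)), and all three sit at the bottom of the scale. Compound 1 `O=C(c1ccncc1)N1N=C(c2ccc(Cl)cc2)CC1c1ccco1` gives 0% in this assay. Compound 2 `COc1ccc(C2CC(c3ccccc3)=NN2C(=O)c2nc3ccccc3s2)cc1` gives 0%. Compound 3 `COc1ccccc1C1=NN(C(=O)c2ccncc2)C(c2ccc([N+](=O)[O-])cc2)C1` gives 0%, which is level with the values of compound 1 and compound 2 at the digits shown; no one of the three can be set apart from the others, and nothing in these numbers hints at a direction.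

The next compound to be measured is compound 4 `COc1ccccc1C1=NN(C(=O)c2ccc([N+](=O)[O-])o2)C(c2ccc([N+](=O)[O-])cc2)C1`. It differs from compound 3 in one place: 5-nitrofuran-2-yl in place of pyridin-4-yl on a carbonyl carbon. Among the compounds with values here, no pair among the measured compounds differs in just one place, so there is no measured step to lean on for this change.

Given that every measured compound lies at the floor of the read-out, the change in compound 4 is expected to move the number by nothing beyond the usual scatter, and the step from compound 3 to compound 4 is estimated as no change at the digits printed from compound 3 to compound 4 (within the scatter). Compound 4 is therefore expected to give about 0% in this assay, with a range from 0% to 10%, because compound 3 gives 0% and a rise beyond the scatter would need support that the shared core has not yet shown.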

Compound 4, a percentage reported as inhibition, at one concentration (the size of the read-out at that concentration, not a potency): 0%
Estimate against measurement, compound 4: no gap at the digits printed; the measured number falls inside the stated range.
By their numbers in this assay, from the lowest: compounds 1, 2, 3 and 4 (each within the scatter of the next).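

Within the data shown here, putting 5-nitrofuran-2-yl in place of pyridin-4-yl on a carbonyl carbon gives no change at the digits printed from compound 3 to compound 4 (within the scatter) in this assay and this is the first step that can be read at any single position. It shows that exchanging a six-membered aromatic ring for a five-membered one carrying a nitro group, on the same amide-type carbonyl, is not enough on its own to lift this shared core off the bottom of the scale. No measurement here explains this flat result.

The compounds shown leave open whether an amine or a carboxylic acid on this carbonyl carbon would raise the number at all. From the compounds shown here alone, with every value so far at the bottom of the scale, a step downward could not be seen in this read-out, so the groups at this position cannot yet be ranked against each other, and any effect of changes elsewhere on the core remains unknown.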